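An Ether Chain Replaces the Alkyne on a Shared Core

The source may report more compounds than this note shows. Statements on the series, on what has been measured and on what is new or still open speak of the compounds shown alone.

Three compounds share one core and differ only in the group on a saturated chain carbon bound to an oxygen on an aromatic ring. Compound 1 `Nc1ccc2cccc(OCC3CCCC3)c2n1` carries a cyclopentyl there, and in an assay on cells with melanin-concentrating hormone receptor 1 (Homo sapiens) as the target, read by radioligand binding (a higher number here means a weaker inhibitor, a lower number a stronger inhibitor), compound 1 gives 53 nM. Compound 2 `CC(C)OCCOc1cccc2ccc(N)nc12` carries isopropoxymethyl instead. In this assay compound 2 reaches only > 2000 nM, which is a limit of the assay and not a number. Compound 3 `CCC#CCOc1cccc2ccc(N)nc12` carries but-1-yn-1-yl. In this assay compound 3 likewise reaches only > 2000 nM, again a limit rather than a number. The two steps that leave the cyclopentyl are both large: an at least 37-fold higher number from compound 1 to compound 2 (1.57 log units; beyond the scatter) and an at least 37-fold higher number from compound 1 to compound 3 (1.57 log units; beyond the scatter). The step that the two limits leave unreadable from compound 2 to compound 3 cannot be read because of the limit of > 2000 nM in this assay, at which 2 of the 3 values shown sit.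

Compound 4 `COCCOCCOc1cccc2ccc(N)nc12` is the next change: (2-methoxyethoxy)methyl in place of but-1-yn-1-yl on a saturated chain carbon bound to an oxygen on an aromatic ring. The entering group is an ether chain like the isopropoxymethyl of compound 2, not a cyclopentyl, so compound 4 is expected to remain at the limit, with a step that the limit leaves unreadable from compound 3 to compound 4 that is expected to stay unreadable. Compound 4 is estimated at 5000 nM, within a range from 1500 nM to 20000 nM.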

Compound 4, half-maximal inhibitory concentration: > 2000 nM
Compound 4 was reported as a limit; the forecaster's own chance of this, stated with the estimate: 80%; the middle value is on the limit's open side.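

Compound 4 also gives no number in this assay: its > 2000 nM is a limit of the assay. The step of an at least 37-fold higher number from compound 1 to compound 4 (1.57 log units; beyond the scatter) is large, so the longer (2-methoxyethoxy)methyl chain joins isopropoxymethyl and but-1-yn-1-yl as a third open-chain group at this position that falls well short of the cyclopentyl of compound 1. The steps among compound 2, compound 3 and compound 4 cannot be read, so these three cannot be ranked: the limit of > 2000 nM in this assay, at which 3 of the 4 values shown sit.

The compounds shown leave open whether it is the ring itself that matters at this position, or simply a chain made only of carbon. A cyclohexyl or phenyl group, or a plain butyl chain, on the same saturated chain carbon would bear on that question.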